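The compounds below may be only part of what the source reports. "The series", "measured", "known", "first", "only" and "open" are said of these compounds alone.

Measured so far:
Compound 1, `CCCC(N)C(=O)NCc1ccccc1`: 120 mg/kg
Compound 2, `CCC[C@@H](N)C(=O)NCc1ccccc1`: 66 mg/kg

In a functional assay on the whole organism (strain NMRI) with Mus musculus as the target, with a stated time of 30 min (a lower number here means that less compound is needed, a higher number that more compound is needed for the effect), compound 1 gives 120 mg/kg, and compound 2 gives 66 mg/kg. The two numbers sit within the scatter of each other, as the step of a 1.8-fold lower number from compound 1 to compound 2 (0.26 log units; within the scatter) shows. That step rests only on (the fact that one of compounds 1 and 2 is drawn with a defined configuration and the other without, at the place where they differ), so it says nothing about what a change in the side chain does.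

Compound 3, `C=CCOCC(N)C(=O)NCc1ccccc1`, differs from compound 1 by allyloxy in place of ethyl on a saturated chain carbon, two bonds along the chain from an amine nitrogen and a carbonyl carbon. For the measured compounds named here, no measured step touches this part of the molecule, and the single step on record, a 1.8-fold lower number from compound 1 to compound 2 (0.26 log units; within the scatter), lies within the scatter. There is therefore no ground to expect a step beyond the scatter in either direction, and the uncertainty is wide. Compound 3 is expected to give about 120 mg/kg, most likely between 40 mg/kg and 350 mg/kg, which amounts to an expected step of no change at the digits printed from compound 1 to compound 3 (within the scatter).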

Compound 3, minimum effective dose: 130 mg/kg
The estimate for compound 3 lay 1.1-fold (0.03 log units) below the measured number, within the range that was stated.
By their numbers in this assay, from the lowest: compounds 2, 1 and 3 (each within the scatter of the next).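

In this assay, for the compounds shown here, the step of a 1.1-fold higher number from compound 1 to compound 3 (0.03 log units; within the scatter) is the first measured change to the side chain itself; the earlier step concerned only how a stereocentre is drawn. At this saturated chain carbon, two bonds along the chain from an amine nitrogen and a carbonyl carbon, allyloxy in place of ethyl brings in an oxygen and a double bond, yet the number cannot be told apart from that of the ethyl compound. Nothing on record explains this result.

The compounds shown leave open whether an amine, a carboxylic acid or a phenyl ring at this carbon would give a step beyond the scatter. They also leave open how an allyloxy compound with a defined configuration at this carbon would compare with compound 3.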